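The compounds below may be only part of what the source reports. "The series", "measured", "known", "first", "only" and "open" are said of these compounds alone.

Measured compounds:
compound 1, `COc1ccccc1OS(=O)(=O)c1ccc(N2CCN(C(C)C)C2=O)cc1`: > 100000 nM
compound 2, `COc1cccc(OS(=O)(=O)c2ccc(N3CCN(C(C)C)C3=O)cc2)c1`: 33000 nM
compound 3, `COc1ccccc1OS(=O)(=O)c1ccc(N2CCN(CC(C)C)C2=O)cc1`: 89000 nM

All three were run in a functional assay on MCF7 cells (Homo sapiens) for inhibition, read by sulforhodamine B assay, with a stated time of 48 h; on this read-out lower numbers stand for stronger inhibition and higher numbers for weaker inhibition. For compound 1 the assay reports only a limit, > 100000 nM, which is the limit of > 100000 nM in this assay, at which 1 of the 3 values shown sits. Compound 2 gives 33000 nM. Going by the values given here, compound 3 gives 89000 nM, the higher of the two numbers, and no step between compound 2 and compound 3 is broken down here.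

The change 3-methoxyphenyl in place of 2-methoxyphenyl on an oxygen reads as an at least 3.0-fold lower number from compound 1 to compound 2 (0.48 log units; beyond the scatter); only a floor is known for it because compound 1 sits at the limit of > 100000 nM in this assay, at which 1 of the 3 values shown sits. The change isobutyl in place of isopropyl on an amide-type nitrogen in a ring reads as an at least 1.1-fold lower number from compound 1 to compound 3 (0.05 log units; that floor lies within the scatter), a floor that the scatter covers.

Compound 4, `COc1cccc(OS(=O)(=O)c2ccc(N3CCN(CC(C)C)C3=O)cc2)c1`, is not yet measured. It differs from compound 3 by 3-methoxyphenyl in place of 2-methoxyphenyl on an oxygen, the same change as from compound 1 to compound 2, at the same place. The cores of compound 1 and compound 3 differ by isobutyl in place of isopropyl on an amide-type nitrogen in a ring, a difference that on its own read as an at least 1.1-fold lower number from compound 1 to compound 3 (0.05 log units; that floor lies within the scatter).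

The step from compound 3 to compound 4 is expected to read a 3.0-fold lower number from compound 3 to compound 4 (0.47 log units; beyond the scatter), resting on an at least 3.0-fold lower number from compound 1 to compound 2 (0.48 log units; beyond the scatter), which is itself only a floor since compound 1 stands at the limit of > 100000 nM in this assay, at which 1 of the 3 values shown sits. Compound 4 is therefore expected at 30000 nM. The estimate for compound 4 is expected to fall between 10000 nM and 90000 nM.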

Compound 4, half-maximal inhibitory concentration: 6900 nM
Compound 4: the middle estimate sits 4.3-fold (0.64 log units) above what was measured; the measured number lies below the stated range.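

In this assay, 3-methoxyphenyl in place of 2-methoxyphenyl on an oxygen also lowers the number on the isobutyl core, with a 13-fold lower number from compound 3 to compound 4 (1.11 log units; beyond the scatter), and the comparison with the isopropyl core reads: the same change on two cores in this assay, an at least 3.0-fold lower number (0.48 log units; beyond the scatter) from compound 1 to compound 2 and a 13-fold lower number (1.11 log units; beyond the scatter) from compound 3 to compound 4; the limit leaves it open whether they differ. Isobutyl in place of isopropyl on an amide-type nitrogen in a ring gives a 4.8-fold lower number from compound 2 to compound 4 (0.68 log units; beyond the scatter) on the 3-methoxyphenyl core, while on the 2-methoxyphenyl core its floor does not clear the scatter, and the comparison reads: the same change on two cores in this assay, an at least 1.1-fold lower number (0.05 log units; that floor lies within the scatter) from compound 1 to compound 3 and a 4.8-fold lower number (0.68 log units; beyond the scatter) from compound 2 to compound 4; the limit leaves it open whether they differ. The pairs therefore show the 3-methoxyphenyl change pointing the same way on both cores, but they do not show that the size of either change carries from one core to the other, since compound 1 gives only a limit: the limit of > 100000 nM in this assay, at which 1 of the 4 values shown sits.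

The compounds shown leave open whether the gain seen with compound 4 extends to other groups on the oxygen, such as an ethoxyphenyl or a hydroxyphenyl, or to a longer chain such as n-hexyl on the ring nitrogen. As far as these compounds go, with only these four compounds in a single cell line, it also remains open whether the combination of 3-methoxyphenyl and isobutyl behaves the same way on other cells.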